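A few compounds are considered here, and "the series" means these few. Any claim that something is new, unique, unknown or untested is made for them only; others in the source may bear on it.

Measured so far:
compound 1 `CCOc1nc(-c2cc3ccccc3o2)cc(-c2ccc(Br)cc2)c1C#N`: 227000 nM
compound 2 `CCOc1nc(-c2cc3ccccc3o2)cc(-c2cc(OC)ccc2OC)c1C#N`: 327000 nM

Both numbers come from a functional assay on aorta (strain Wistar) for inhibition, with Thoracic aorta (Rattus norvegicus) as the target; a lower number here means a stronger inhibitor, a higher number a weaker inhibitor. Among the measured compounds shown here, compound 2 stands at the higher of the two numbers, with compound 1 as its only neighbour, but the step of a 1.4-fold higher number from compound 1 to compound 2 (0.16 log units; within the scatter) lies within the scatter, so no order between the two is claimed; both groups at this place of the shared core behave alike here.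

Compound 3 `CCOc1nc(-c2cc3ccccc3o2)cc(-c2ccc(C)o2)c1C#N` has not yet been measured in this assay. It differs from compound 2 by 5-methylfuran-2-yl in place of 2,5-dimethoxyphenyl on an aromatic carbon. For the measured compounds named here, the only measured step that bears on this place is a 1.4-fold higher number from compound 1 to compound 2 (0.16 log units; within the scatter), and it was within the scatter. Going by the values given here, no measured step covers a five-membered aromatic ring at this place. The expectation for this assay is therefore a step no larger than the scatter, in no preferred direction, as a 1.1-fold lower number from compound 2 to compound 3 (0.05 log units; within the scatter). Compound 3 is estimated at 290000 nM, with a range from 100000 nM to 850000 nM.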

Compound 3, half-maximal inhibitory concentration: 417000 nM
Compound 3: middle estimate off by 1.4-fold (0.16 log units), on the low side, within the range that was stated.
By their numbers in this assay, from the lowest: compounds 1, 2 and 3 (each within the scatter of the next).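

In this assay, a five-membered aromatic ring with 1 hetero atom now stands at this place, opposite the ring nitrogen, and the change gives a 1.3-fold higher number from compound 2 to compound 3 (0.11 log units; within the scatter) and, measured against the 4-bromophenyl compound, a 1.8-fold higher number from compound 1 to compound 3 (0.26 log units; within the scatter), so both steps stay within the scatter. The place therefore accepts 5-methylfuran-2-yl, 2,5-dimethoxyphenyl and 4-bromophenyl without a readable difference. The earlier comparison covered two six-membered aromatic rings of carbon only, and the same now holds for a smaller ring carrying a hetero atom. Nothing available explains this flat behaviour.

From the compounds shown here alone, all three groups at this place are aromatic rings with no net charge, so it remains open whether an aminomethyl group, a carboxylic acid or a longer alkyl chain there would move the number beyond the scatter. Also open, going by these compounds, is whether replacing the ethoxy group or the 1-benzofuran-2-yl group would do so.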